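The source may report more compounds than this note shows. Statements on the series, on what has been measured and on what is new or still open speak of the compounds shown alone.

Measured in an ADME assay on MDCK cells (Canis lupus familiaris) for cytotoxicity; on this read-out higher numbers stand for lower toxicity in this test and lower numbers for higher toxicity in this test:
Compound 1 `CC(=O)Nc1ccc2oc(-c3ccnc(C(=O)N4CCN(C(c5nnn(C)n5)c5ccccc5F)CC4)c3)nc2c1`: > 50000 nM
Compound 2 `CC(=O)Nc1ccc2oc(-c3ccnc(C(=O)N4CCN(C(c5cccc(F)c5)c5nnn(C)n5)CC4)c3)nc2c1`: > 50000 nM

Both entries are limits of the assay and not numbers. Compound 2 gives > 50000 nM, so it has only a limit and no exact position. Compound 3 `CC(=O)Nc1ccc2oc(-c3ccnc(C(=O)N4CCN(C(c5ccc(F)cc5)c5nnn(C)n5)CC4)c3)nc2c1` has not yet been measured. It differs from compound 2 as follows: 4-fluorophenyl in place of 3-fluorophenyl on a saturated chain carbon bound to an amine nitrogen in a ring and an aromatic carbon. In words, 4-fluorophenyl stands in place of 3-fluorophenyl on a saturated chain carbon bound to an amine nitrogen in a ring and an aromatic carbon.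

For the measured compounds named here, one measured step bears on this change, the swap of 2-fluorophenyl for 3-fluorophenyl at the same place: a step that the two limits leave unreadable from compound 1 to compound 2. It gives no size to carry over. The data show only (the limit of > 50000 nM in this assay, at which 2 of the 2 values shown sit). In this assay, no step beyond the scatter is therefore expected, in either direction. The expected step is a number no higher from compound 2 to compound 3 (the limit leaves the size open). Compound 3 is estimated at 50000 nM, with an expected range from 30000 nM to 80000 nM, most likely reported as a limit again.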

Compound 3, half-maximal cytotoxic concentration: > 50000 nM
Compound 3 ended at the assay's limit; the forecaster's own chance of this, stated with the estimate: 90%; the middle value sits exactly at the limit.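

Compound 1, compound 2 and compound 3 are all reported only as limits, not as numbers, so no step among them can be read in this assay: the limit of > 50000 nM in this assay, at which 3 of the 3 values shown sit.

The compounds shown leave open whether 2-fluorophenyl, 3-fluorophenyl and 4-fluorophenyl at this place differ at all in this assay.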